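Working notes on a chloro-to-hydrogen step

The source may hold more compounds than are shown below. What is called first, only, known or untested is meant among the compounds shown, and "the series" means these compounds.

- compound 1 `COc1ccc(-c2nc3sc(-c4ccccc4)cn3n2)cc1`: 28%
- compound 2 `Clc1ccc(-c2cn3nc(-c4ccccc4)nc3s2)cc1`: 33%

Among the compounds with values here, in a functional assay on NCI-H23 cells (Homo sapiens) for inhibition, read by sulforhodamine B assay, with a stated time of 48 h, tested at 10 uM (a lower number here means less inhibition of growth, a higher number more inhibition of growth at the concentration tested), compound 2 at 33% stands within the scatter of compound 1, the only other measured compound. Compound 3 `c1ccc(-c2nc3sc(-c4ccccc4)cn3n2)cc1` follows from compound 2 by the change (hydrogen in place of chloro on an aromatic carbon) that puts hydrogen in place of chloro on an aromatic carbon. Within the data shown here, no measured pair differs in one place only, so no measured step guides this expectation. Expected in this assay is a number 7 percentage points lower from compound 2 to compound 3 (within the scatter) as a small downward move that stays within the scatter. For compound 3 the estimated value is 26% (range 10% to 42%).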

Compound 3, percent growth inhibition at one concentration: 16%
Compound 3: the middle estimate sits 10 percentage points above what was measured; the measured number falls inside the stated range.
By their numbers in this assay, from the lowest: compound 3; then compounds 1 and 2 (each within the scatter of the next).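

In this assay the 4-chlorophenyl to phenyl change gives a number 17 percentage points lower from compound 2 to compound 3 (beyond the scatter) and removing the methoxy group gives a number 12 percentage points lower from compound 1 to compound 3 (beyond the scatter) so both steps to the bare phenyl compound lose growth inhibition. The chloro at this position therefore contributes to the read-out, which the first two compounds alone could not show. No available data explain the loss.

As far as these compounds go, whether fluoro, an amine or a carboxylic acid at this position would match chloro remains open. Inhibition above the level of compound 2 also remains open.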